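Swapping chloro for hydrogen on a weak inhibitor

The source may hold more compounds than are shown below. What is called first, only, known or untested is meant among the compounds shown, and "the series" means these compounds.

In a functional assay on CCRF-CEM cells (Homo sapiens) for inhibition (a higher number here means a weaker inhibitor, a lower number a stronger inhibitor), compound 1 `O=C(/C=C/C=C/C[S+]([O-])c1ccc(Cl)cc1)NO` has no usable result, its entry reading "not determined" (no result reported). Compound 2 `O=C(CCCCCSc1ccc(Cl)cc1)NO` stands at > 25000 nM, which is a limit of the assay and not a number. Compound 3 `O=C(CCCCCSc1ccccc1)NO` has hydrogen in place of chloro on an aromatic carbon, para to a large group (hydrogen in place of chloro on an aromatic carbon). Among the compounds with values here, no measured pair in this small set shows what such a swap does. A small shift towards a lower number is expected, the estimated step being an at least 1.2-fold lower number from compound 2 to compound 3 (0.09 log units; that floor lies within the scatter). For compound 3 the estimate is 20000 nM, with an expected range from 8000 nM to 30000 nM.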

Compound 3, half-maximal inhibitory concentration: > 25000 nM
Compound 3: no number, only a limit; the forecaster's own chance of this, stated with the estimate: 60%; middle value at least 1.2-fold (0.09 log units) away from the limit.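

Within the data shown here, compound 2 and compound 3 both give only a limit, not a number, so no step between them can be read: the limit of > 25000 nM in this assay, at which 2 of the 3 values shown sit. As far as these compounds go, whether swapping chloro for hydrogen changes inhibition at all remains open, as does the true strength of either compound.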